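The source may report more compounds than this note shows. Statements on the series, on what has been measured and on what is new or still open speak of the compounds shown alone.

Measured in an in vitro ADME assay on microsomes from liver (Homo sapiens) for metabolic stability, with a stated time of 60 min, tested at 1 uM; a higher number here means faster removal of the compound, a lower number slower removal:
- Compound 1 `COc1cc(-c2cc(-c3ccc(S(C)(=O)=O)cc3)cnc2N)ccc1O`: 17 mL.min-1.g-1
- Compound 2 `CS(=O)(=O)c1ccc(-c2cnc(N)c(-c3ccc(C(F)(F)F)c(F)c3)c2)cc1`: 14 mL.min-1.g-1
- Compound 3 `CS(=O)(=O)c1ccc(-c2cnc(N)c(-c3ccc(C(F)(F)F)cc3)c2)cc1`: < 7 mL.min-1.g-1

For compound 3, the entry < 7 mL.min-1.g-1 is a limit of the assay and not a number. Compound 4 `CNC(=O)c1ccc(-c2cc(-c3ccc(S(C)(=O)=O)cc3)cnc2N)cc1` keeps the shared core of compound 3, but methylcarbamoyl takes the place of trifluoromethyl on an aromatic carbon, para to a large group: methylcarbamoyl in place of trifluoromethyl on an aromatic carbon.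

Within the data shown here, no measured step covers this swap. Among the measured compounds shown here, the one measured step that comes closest is an at least 2.0-fold lower number from compound 2 to compound 3 (0.30 log units; that floor lies within the scatter). It puts hydrogen in place of fluoro on an aromatic carbon, which is a different change, so it is only a loose guide to size. With so little to go on, no step beyond the usual scatter is expected in this assay, and no direction can be favoured with confidence. The estimated step is a step that the limit leaves unreadable from compound 3 to compound 4. Compound 4 is expected at 6 mL.min-1.g-1, with an estimated range of 3 mL.min-1.g-1 to 13 mL.min-1.g-1.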

Compound 4, intrinsic clearance in microsomes: < 5 mL.min-1.g-1
Compound 4 ended at the assay's limit; the forecaster's own chance of this, stated with the estimate: 60%; middle value at least 1.2-fold (0.07 log units) from the limit.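

In this assay, among these compounds, compound 3 and compound 4 both end at limits of the assay and not at numbers, and no step between them can be read. The compounds shown leave open how large the effect of methylcarbamoyl in place of trifluoromethyl is, and in which direction it goes.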